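Rearranging the Amine Ring on the Amide Nitrogen

A few compounds are considered here, and "the series" means these few. Any claim that something is new, unique, unknown or untested is made for them only; others in the source may bear on it.

Measured so far in an ADME assay on cells (Hepatocyte, Rattus norvegicus) for metabolic stability; a higher number here means faster removal of the compound, a lower number slower removal:
- compound 1, `Cc1ccc2[nH]c(C(=O)N[C@H]3CN(S(=O)(=O)c4ccccc4)C[C@@H]3C(=O)NC[C@H]3CCCN3)cc2c1`, gives 10 uL/min
- compound 2, `Cc1ccc2[nH]c(C(=O)N[C@H]3CN(S(=O)(=O)c4ccccc4)C[C@@H]3C(=O)NC[C@H]3CCCN3C)cc2c1`, gives 21 uL/min

Among the measured compounds shown here, compound 2 stands at the higher of the two numbers in this assay; its only neighbour is compound 1, and the step of a 2.1-fold higher number from compound 1 to compound 2 (0.32 log units; beyond the scatter) separates them. Compound 3, `Cc1ccc2[nH]c(C(=O)N[C@H]3CN(S(=O)(=O)c4ccccc4)C[C@@H]3C(=O)N[C@@H]3CCCN(C)C3)cc2c1`, has not yet been measured. It differs from compound 2 in one place: 1-methylpiperidin-3-yl in place of (1-methylpyrrolidin-2-yl)methyl on an amide-type nitrogen. For the measured compounds named here, the single measured step, a 2.1-fold higher number from compound 1 to compound 2 (0.32 log units; beyond the scatter), changes a different part of the molecule, a methyl in place of hydrogen on an amine nitrogen in a ring, and nothing measured here swaps one saturated ring for another or moves the ring closer to the amide nitrogen. Going by the values given here, with no step bearing on this change, the expected step is none beyond the scatter, no change at the digits printed from compound 2 to compound 3 (within the scatter). Compound 3 is therefore estimated at 21 uL/min in this assay, within a range from 9 uL/min to 48 uL/min.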

Compound 3, intrinsic clearance in a liver preparation (reported as CLH), per the amount of preparation that the assay uses: 23 uL/min
For compound 3 the middle estimate is 1.1-fold (0.04 log units) below the measured one; measured number inside the range.
By their numbers in this assay, from the lowest: compound 1; then compounds 2 and 3 (each within the scatter of the next).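

In this assay, putting 1-methylpiperidin-3-yl in place of (1-methylpyrrolidin-2-yl)methyl on the amide-type nitrogen gives a 1.1-fold higher number from compound 2 to compound 3 (0.04 log units; within the scatter), so at this position, a six-membered ring can replace a five-membered one without a change that stands out from the scatter. Measured against (pyrrolidin-2-yl)methyl, the group without the methyl on its ring nitrogen, the same new group gives a 2.3-fold higher number from compound 1 to compound 3 (0.36 log units; beyond the scatter), so the gap first seen with compound 2 is still present after the ring change. Nothing measured here explains these numbers.

On these data alone, it remains open whether piperidin-3-yl, with a hydrogen in place of that methyl, would return to the level of compound 1 at 10 uL/min. A morpholine ring or a longer chain at this nitrogen also remains untested in the compounds shown.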